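This account rests on a few compounds, and the source may have more. Where it says the series, first, only, none or still open, it means among the compounds named here.

Measured so far:
compound 1, `O=C(/C=C1\CCc2ccc(F)cc21)NCC1CC1`: 50%
compound 2, `CON(C)C(=O)/C=C1\CCc2ccc(F)cc21`: 17%

Compound 2 stands lowest of the two numbers in a functional assay on the whole organism with Mus musculus as the target, at a dose of 100 mg/kg by the intraperitoneal route; a lower number here means less inhibition, a higher number more inhibition at the dose given (going by the name of the read-out); the nearest is compound 1, whose value lies higher, beyond the scatter. Among the compounds with values here, the one measured step is a number 33 percentage points lower from compound 1 to compound 2 (beyond the scatter), a change of the whole group on the carbonyl carbon. Compound 3, `CCN(C)C(=O)/C=C1\CCc2ccc(F)cc21`, differs from compound 2 in a smaller way: ethyl in place of methoxy on an amide-type nitrogen. Within the data shown here, no measured step touches the methoxy on the amide-type nitrogen, so the step from compound 1 to compound 2 bears on the present one only loosely, as a sign that the group on that nitrogen can matter. Compound 3 is expected to stay near compound 2, with a step of a number 7 percentage points higher from compound 2 to compound 3 (within the scatter), not clearly beyond the scatter in either direction. The estimate for compound 3 is 24%, in the range 5% to 48%.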

Compound 3, a percentage reported as inhibition, in the whole organism at one dose (the size of the read-out at that dose, not a potency): 100%
Estimate against measurement, compound 3: 76 percentage points below; the measured number lies above the stated range.
By their numbers in this assay, from the lowest: compound 2; then compound 1; then compound 3.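

In this assay the exchange of methoxy for ethyl on the amide-type nitrogen, with the methyl kept, is enough on its own to give a number 83 percentage points higher from compound 2 to compound 3 (beyond the scatter) and so to move the number by a large amount. The low number of compound 2 therefore does not come with simply having two groups on that nitrogen, since compound 3 has two as well and the change of ethyl(methyl)amino for (cyclopropylmethyl)amino on the carbonyl carbon gives a number 50 percentage points higher from compound 1 to compound 3 (beyond the scatter) in the upward direction. No evidence at hand bears on what lies behind this difference.

On these data alone, whether a longer chain such as propyl or a smaller methyl in place of the ethyl keeps the number up remains open, as does a ring amine such as pyrrolidine on the carbonyl carbon. Read at a single dose, these numbers leave the potency of compound 3 open too.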